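This account rests on a few compounds, and the source may have more. Where it says the series, first, only, none or still open, it means among the compounds named here.

The compounds measured so far:
compound 1 `O=C1C(Nc2cccc(Cl)c2)=CC(=O)c2c1nc1n2[C@H]2OC[C@@H](O)[C@H]2OC1` — 3080 nM
compound 2 `O=C1C=C(Nc2ccccc2)C(=O)c2c1nc1n2[C@H]2OC[C@@H](O)[C@H]2OC1` — 4970 nM
compound 3 `O=C1C(N2CCC2)=CC(=O)c2c1nc1n2[C@H]2OC[C@@H](O)[C@H]2OC1` — a limit, > 16000 nM

In a functional assay on ECa-109 cells for inhibition, with ECa-109 cell line (Homo sapiens) as the target, read by sulforhodamine B assay (a lower number here means a stronger inhibitor, a higher number a weaker inhibitor), compound 2 gives 4970 nM. Of the two numbers reported, compound 1 gives 3080 nM, and the gap between compound 2 and compound 1 lies within the usual scatter. Compound 3 gives only a limit in this assay, > 16000 nM, and that is the limit of > 16000 nM in this assay, at which 1 of the 3 values shown sits.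

Compound 4 `O=C1C=C(N2CCC2)C(=O)c2c1nc1n2[C@H]2OC[C@@H](O)[C@H]2OC1` has not yet been measured. Against compound 2 the change is azetidin-1-yl in place of anilino on a double-bonded ring carbon. Among the measured compounds shown here, one measured step bears on it: the same kind of exchange, azetidin-1-yl entering on a double-bonded ring carbon, was made from compound 1 to compound 3, where an at least 5.1-fold higher number from compound 1 to compound 3 (0.71 log units; beyond the scatter), with the end point a limit. Compound 4 is therefore expected to be weaker than compound 2 in this assay by a step of about a 5.0-fold higher number from compound 2 to compound 4 (0.70 log units; beyond the scatter), quite possibly past the limit. Compound 4 is estimated at 25000 nM, with a range from 8000 nM to 80000 nM.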

Compound 4, half-maximal inhibitory concentration: > 16000 nM
Compound 4: a limit, no number; the forecaster's own chance of this, stated with the estimate: 75%; the middle value is on the limit's open side.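

In this assay, azetidin-1-yl in place of anilino gives an at least 3.2-fold higher number from compound 2 to compound 4 (0.50 log units; beyond the scatter). The loss seen earlier with azetidin-1-yl therefore also appears when plain anilino leaves, and on a different double-bonded ring carbon from the one that carries azetidin-1-yl in compound 3. The value of compound 4 is a limit, the same limit that compound 3 reached: the limit of > 16000 nM in this assay, at which 2 of the 4 values shown sit.

As far as these compounds go, with both azetidin-1-yl compounds at that limit, their order cannot be read, and the true size of the step from anilino remains unknown. From the compounds shown here alone, the exchange removes the aromatic ring and the hydrogen-bond donor together, so it remains open which of them matters; methyl(phenyl)amino, which keeps the ring without the donor, and cyclopropylamino, which keeps the donor without the aromatic ring, would separate the two.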